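Two Fluorines in Place of One on the Anilide Ring

The compounds below may be only part of what the source reports. "The series", "measured", "known", "first", "only" and "open" are said of these compounds alone.

Of the compounds shown here, three sharing one core have been tested in a functional assay on A549 cells (Homo sapiens) for cytotoxicity, read by MTT assay, with a stated time of 72 h; on this read-out higher numbers stand for weaker inhibition and lower numbers for stronger inhibition. Compound 1 `O=C(CN1CCN(c2nnc(Cc3ccncc3)c3ccccc23)CC1)Nc1cccc(F)c1` gives 4600 nM in this assay, the lowest of the two numbers recorded. Compound 2 `O=C(CN1CCN(c2nnc(Cc3ccccc3)c3ccccc23)CC1)Nc1ccc(F)c(F)c1`, which carries a different group both on the core and on the anilide nitrogen, gives 10100 nM, a gap from compound 1 that lies beyond the usual scatter. Compound 3 `Cc1ccc(NC(=O)CN2CCN(c3nnc(Cc4ccccc4)c4ccccc34)CC2)c(C)c1` gives "not active" (no number reported) in this assay, with no number given.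

Compound 4 `O=C(CN1CCN(c2nnc(Cc3ccncc3)c3ccccc23)CC1)Nc1c(F)cccc1F` differs from compound 1 in one place only: 2,6-difluorophenyl in place of 3-fluorophenyl on an amide-type nitrogen. Going by the values given here, no pair among the measured compounds differs in exactly this way, so nothing in the measured set shows directly what such a swap does. The anilide ring is changed in all three measured compounds at once with other parts, and the spread among them is modest, apart from compound 3 giving no number at all.

Given that, the step from compound 1 to compound 4 is expected to be small, a 1.3-fold higher number from compound 1 to compound 4 (0.12 log units; within the scatter), most likely within the scatter or at most a slight weakening. Compound 4 is therefore estimated at 6000 nM, with a likely range from 2500 nM to 15000 nM.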

Compound 4, half-maximal inhibitory concentration: 54400 nM
Beside the measured number, compound 4's estimate is 9.1-fold (0.96 log units) below it; the whole stated range lies below it.
By their numbers in this assay, from the lowest: compound 1; then compound 2; then compound 4.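

Going by these compounds alone, this is the first comparison in the set in which only the anilide ring changes, and in this assay the step to 2,6-difluorophenyl is large: a 12-fold higher number from compound 1 to compound 4 (1.07 log units; beyond the scatter). The earlier compounds shown here could not show this, since compound 1 and compound 2 differ in more than one place and compound 3 gives no number, so the modest spread between the first two numbers said little about this ring alone. The step shows that, with the rest of compound 1 held fixed, cytotoxicity in these cells depends strongly on which fluorinated phenyl group sits on the amide-type nitrogen, although nothing available explains why this swap has so large an effect.

This one step changes both the number of fluorines and their places on the ring, so it cannot tell which of the two matters, and a plain phenyl group or a pyridyl group on the same nitrogen would help to separate them. It also leaves open whether the same swap would have a similar effect on the core of compound 2, which carries a different group.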